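Hydrogen in place of methyl on compound 3

A few compounds are considered here, and "the series" means these few. Any claim that something is new, unique, unknown or untested is made for them only; others in the source may bear on it.

In a functional assay on HCT-116 cells (Homo sapiens) for inhibition, read by resazurin assay, with a stated time of 5 days (a lower number here means a stronger inhibitor of growth, a higher number a weaker inhibitor of growth), compound 1 `O=C(CCCC1CCN(S(=O)(=O)Cc2ccccc2)CC1)NO` gives 3200 nM and compound 2 `O=C(CCCC1CCN(S(=O)(=O)c2ccccc2Cl)CC1)NO` gives 2800 nM. Compound 3 `Cc1cc(S(=O)(=O)N2CCC(CCCC(=O)NO)CC2)cc2ccccc12` has the highest of the three numbers at 17300 nM, beyond the scatter of both others. Compound 4 `O=C(CCCC1CCN(S(=O)(=O)c2ccc3ccccc3c2)CC1)NO` differs from it by hydrogen in place of methyl on an aromatic carbon. For the measured compounds named here, the one measured step, a 1.1-fold lower number from compound 1 to compound 2 (0.06 log units; within the scatter), lies within the scatter, but it exchanges benzyl for 2-chlorophenyl on a sulfonyl sulfur, so no measured step covers this methyl. Partial movement towards compound 1 at 3200 nM is assumed, with wide uncertainty. The expected change is a 2.5-fold lower number from compound 3 to compound 4 (0.39 log units; beyond the scatter), towards a lower number. Compound 4 is estimated at 7000 nM, with an expected range from 2500 nM to 17000 nM.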

Compound 4, concentration for 50% growth inhibition: 1900 nM
Compound 4: the middle estimate sits 3.7-fold (0.57 log units) above what was measured; measured number outside the range, below it.
By their numbers in this assay, from the lowest: compounds 4, 2 and 1 (each within the scatter of the next); then compound 3.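

Hydrogen in place of methyl on this aromatic carbon, ortho to a fused ring, gives a 9.1-fold lower number from compound 3 to compound 4 (0.96 log units; beyond the scatter) in this assay. A single heavy atom at this position therefore produces a step beyond the scatter, unlike the earlier exchange on the sulfonyl sulfur, a 1.1-fold lower number from compound 1 to compound 2 (0.06 log units; within the scatter). Nothing available explains the size of this step.

Only methyl and hydrogen are compared at this carbon, so the series does not show whether the step is specific to methyl. Fluorine, methoxy or an amine at the same carbon would test this.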